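Isopropyl for methyl on sulfur: a step from a limit

This account rests on a few compounds, and the source may have more. Where it says the series, first, only, none or still open, it means among the compounds named here.

Of the compounds shown here, three sharing a core have been tested in a functional assay on MT4 cells (Homo sapiens) for cytotoxicity; on this read-out higher numbers stand for lower toxicity in this test and lower numbers for higher toxicity in this test. Compound 1, `CSc1nc(O)cc(C(C)c2c(F)cccc2F)n1`, gives 20800 nM. Compound 2, `CC(C)Sc1nc(O)cc(C(C)c2c(F)cccc2F)n1`, differs from it by isopropyl in place of methyl on a sulfur; in this assay compound 2 gives 167000 nM. That change made a step of an 8.0-fold higher number from compound 1 to compound 2 (0.90 log units; beyond the scatter).

Compound 3, `CSc1nc(O)c(C)c(C(C)c2c(F)cccc2F)n1`, carries a different core, which differs from the core of compound 1 by methyl in place of hydrogen on an aromatic carbon. For compound 3 the read-out is not a number but a limit of the assay: the limit of > 200000 nM in this assay, at which 1 of the 3 values shown sits. In this assay compound 3 is reported as > 200000 nM. Compared with compound 1, this limit means a step of an at least 9.6-fold higher number from compound 1 to compound 3 (0.98 log units; beyond the scatter).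

Compound 4, `Cc1c(O)nc(SC(C)C)nc1C(C)c1c(F)cccc1F`, has not yet been measured. It differs from compound 3 by isopropyl in place of methyl on a sulfur, the same change as that from compound 1 to compound 2, made at the same place, a sulfur whose other neighbour is an aromatic carbon. Since compound 3 already sits at the limit, compound 4 is expected to return a limit as well, corresponding to a step that the limit leaves unreadable from compound 3 to compound 4. That expectation rests on the earlier step, an 8.0-fold higher number from compound 1 to compound 2 (0.90 log units; beyond the scatter), which raised the number by a modest amount. Compound 4 is therefore estimated at 450000 nM, with the range 200000 nM to 1600000 nM.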

Compound 4, half-maximal cytotoxic concentration: 200000 nM
For compound 4 the middle estimate is 2.3-fold (0.35 log units) above the measured one; the range from low to high includes it.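

In this assay compound 3 gives > 200000 nM, which is a limit of the assay, so the size of the step that starts from it cannot be read, and these values do not explain how that step arises. Even so, swapping methyl for isopropyl on the sulfur gives a number no higher from compound 3 to compound 4 (the limit leaves the size open) and so no matching step on the two cores, which means that the earlier step could not simply be carried over to the core of compound 3: the same change on two cores in this assay, an 8.0-fold higher number (0.90 log units; beyond the scatter) from compound 1 to compound 2 and a number no higher (the limit leaves the size open) from compound 3 to compound 4, at least 8.0-fold (0.90 log units) apart, beyond the scatter of two such steps

Seen from the other side, adding the methyl on the aromatic carbon gives a 1.2-fold higher number from compound 2 to compound 4 (0.08 log units; within the scatter), so the two changes do not simply add up here, although two cores are too few to show whether this holds anywhere else in the series: the same change on two cores in this assay, an at least 9.6-fold higher number (0.98 log units; beyond the scatter) from compound 1 to compound 3 and a 1.2-fold higher number (0.08 log units; within the scatter) from compound 2 to compound 4, at least 8.0-fold (0.90 log units) apart, beyond the scatter of two such steps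

The compounds shown leave open how an ethyl group or a longer chain such as n-butyl on the sulfur would behave on either core, and whether an amine in place of the sulfur-linked group would follow the same pattern. They also leave open how far compound 3 lies past its limit, and with it the true size of the isopropyl step on that core.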